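A few compounds are considered here, and "the series" means these few. Any claim that something is new, unique, unknown or untested is made for them only; others in the source may bear on it.

Measured in a functional assay on UACC-62 cells (Homo sapiens); a lower number here means a stronger inhibitor of growth, a higher number a weaker inhibitor of growth:
- compound 1 `O=S(=O)(/C=C/c1ccccc1)Cc1ccc(Nc2ncnc3ccccc23)cc1`: > 100000 nM, a limit
- compound 2 `O=S(=O)(/C=C/c1ccc(F)cc1F)Cc1ccc(Nc2ncnc3ccccc23)cc1`: > 100000 nM, a limit

Compound 2 has no numerical value in this assay, only the limit of > 100000 nM. Both measured compounds sit at the same point: the limit of > 100000 nM in this assay, at which 2 of the 2 values shown sit.

The next compound is compound 3 `O=S(=O)(/C=C/c1ccc(O)cc1)Cc1ccc(Nc2ncnc3ccccc23)cc1`, which differs from compound 2 as follows: 4-hydroxyphenyl in place of 2,4-difluorophenyl on a double-bonded chain carbon bound to a double-bonded chain carbon. In words, 4-hydroxyphenyl stands in place of 2,4-difluorophenyl on a double-bonded chain carbon bound to a double-bonded chain carbon.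

For the measured compounds named here, one measured step bears on this change, as it falls at the same place: a step that the two limits leave unreadable from compound 1 to compound 2. Its size cannot be read, so it offers no magnitude to carry over, and the series has no measured number to anchor a prediction. Going by the values given here, the only guide is compound 2 at > 100000 nM, so compound 3 is expected to remain near that limit, and another limit is the likeliest report. If a number is obtained, it is expected to fall modestly on the stronger side.

The expected change is small: an at least 1.4-fold lower number from compound 2 to compound 3 (0.15 log units; that floor lies within the scatter). For compound 3 the estimate is 70000 nM, with an expected range of 20000 nM to 100000 nM.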

Compound 3, concentration for 50% growth inhibition: 100000 nM
Compound 3: middle estimate off by 1.4-fold (0.15 log units), on the low side; the measured number falls inside the stated range.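

In this assay, for the compounds shown here, compound 3 gives 100000 nM, the only actual number among the three compounds, with 4-hydroxyphenyl on a double-bonded chain carbon bound to a double-bonded chain carbon. That number coincides with the figure of the limit held by the other two compounds, so the size of each step to the new value cannot be read; the data show only a number no higher from compound 2 to compound 3 (the limit leaves the size open). Hydroxy in place of hydrogen on an aromatic carbon therefore yields a reportable value but no demonstrated gain in growth inhibition, and the series remains mostly at the limit: the limit of > 100000 nM in this assay, at which 2 of the 3 values shown sit.

Going by these compounds, how far compound 1 and compound 2 lie from compound 3 remains open, so any real contribution of the hydroxy cannot yet be separated from the edge of the assay range. On these data alone, also open, with only a number no higher from compound 1 to compound 3 (the limit leaves the size open) in hand, is whether an amine or a carboxylic acid in place of the hydroxy would bring a number clearly on the stronger side.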